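From 4-hydroxybut-1-yn-1-yl to 2-hydroxyphenyl on the shared core

A few compounds are considered here, and "the series" means these few. Any claim that something is new, unique, unknown or untested is made for them only; others in the source may bear on it.

In an ADME assay (liver) for metabolic stability, with Liver microsome (Rattus norvegicus) as the target, using microsomes and NADPH, with a stated time of 30 min, tested at 1 uM (a higher number here means faster removal of the compound, a lower number slower removal), compound 1 `Nc1ccc(S(=O)(=O)N2CCN(c3ncc(C(O)(C(F)(F)F)C(F)(F)F)cc3Br)CC2)cn1` gives 32 mL.min-1.g-1, compound 2 `Nc1ccc(S(=O)(=O)N2CCN(c3ncc(C(O)(C(F)(F)F)C(F)(F)F)cc3C#CCO)CC2)cn1` gives 65 mL.min-1.g-1 and compound 3 `Nc1ccc(S(=O)(=O)N2CCN(c3ncc(C(O)(C(F)(F)F)C(F)(F)F)cc3C#CCCO)CC2)cn1` gives 68 mL.min-1.g-1. Compound 3 stands level with compound 2, as a 1.0-fold higher number from compound 2 to compound 3 (0.02 log units; within the scatter) lies within the scatter. Both stand beyond the scatter above the bromo compound, through the modest steps of a 2.0-fold higher number from compound 1 to compound 2 (0.31 log units; beyond the scatter) and a 2.1-fold higher number from compound 1 to compound 3 (0.33 log units; beyond the scatter). Compound 4 `Nc1ccc(S(=O)(=O)N2CCN(c3ncc(C(O)(C(F)(F)F)C(F)(F)F)cc3-c3ccccc3O)CC2)cn1` carries 2-hydroxyphenyl in place of 4-hydroxybut-1-yn-1-yl on an aromatic carbon. Among the compounds with values here, no measured compound carries that group, so only these modest replacements of bromo and the flat step between the two chains bear on it, and no step beyond the scatter is expected. The expected change in this assay is a 1.1-fold lower number from compound 3 to compound 4 (0.05 log units; within the scatter). The estimate for compound 4 is 60 mL.min-1.g-1, with an expected range of 30 mL.min-1.g-1 to 120 mL.min-1.g-1.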

Compound 4, intrinsic clearance in microsomes: 125 mL.min-1.g-1
Compound 4: middle estimate off by 2.1-fold (0.32 log units), on the low side, and the stated range ends below it.
By their numbers in this assay, from the lowest: compound 1; then compounds 2, 3 and 4 (each within the scatter of the next).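

In this assay the 2-hydroxyphenyl group, with its aromatic ring of carbon only, stands level with both alkynyl chains at this position: a 1.8-fold higher number from compound 3 to compound 4 (0.26 log units; within the scatter) and a 1.9-fold higher number from compound 2 to compound 4 (0.28 log units; within the scatter) each lie within the scatter. Only bromo stands apart, through a 3.9-fold higher number from compound 1 to compound 4 (0.59 log units; beyond the scatter). Across these compounds, a ring in place of a triple-bonded chain therefore does not separate the groups that carry hydroxy.

No supporting data here explain the gap from bromo. Open, on these data alone, is how a plain phenyl, or a chain ending in an amine, would compare.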